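Chloro for Fluoro on a Furan-Linked Amidine Pair

The source may report more compounds than this note shows. Statements on the series, on what has been measured and on what is new or still open speak of the compounds shown alone.

Two amidines of related build have been examined in an ADME assay on cells (Erythrocyte, Homo sapiens) for activation, read by hemolysis, with a stated time of 30 min, tested at 5 mM; on this read-out lower numbers stand for a weaker effect and higher numbers for a stronger effect at the one concentration tested. Compound 1, `N=C(N)c1ccc(-c2ccc(-c3cncc4ccccc34)s2)s1`, is the weaker of the pair: in this assay compound 1 gives 4%. Compound 2, `N=C(N)c1ccc(-c2ccc(-c3ccc(F)cc3)o2)o1`, stands highest of the two numbers shown; in this assay compound 2 gives 66.3%, a reading far above that of compound 1 and well beyond the usual scatter of repeated measurements. For the measured compounds named here, no step between two measured compounds differing in one place is available, so the effect of a single substituent change on hemolysis has not yet been seen directly within this set.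

Compound 3, `N=C(N)c1ccc(-c2ccc(-c3ccc(Cl)cc3)o2)o1`, differs from compound 2 in one place only: chloro in place of fluoro on an aromatic carbon. Everything else in the molecule is kept. Given how close the two structures are, the step from compound 2 to compound 3 in this assay is expected to be small, either none beyond the scatter or a slight rise, as a number 3.7 percentage points higher from compound 2 to compound 3 (within the scatter) expresses. On that basis compound 3 is estimated to give 70% in this assay, with a plausible range from 45% to 90%.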

Compound 3, a percentage reported as activity, at one concentration (the size of the read-out at that concentration, not a potency): 70.7%
Compound 3: middle estimate off by 0.7 percentage points, on the low side; low and high end bracket the measured number.
By their numbers in this assay, from the lowest: compound 1; then compounds 2 and 3 (each within the scatter of the next).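

With compound 3 the set gains its first step in one place, and in this assay chloro in place of fluoro gives a number 4.4 percentage points higher from compound 2 to compound 3 (within the scatter) and so leaves the reading within the scatter. The change sits on an aromatic carbon of a six-membered aromatic ring of carbon only, para to a large group, and at this place the two groups cannot be told apart by this read-out, which compound 2 alone could not show. Compound 1 differs from compound 2 and compound 3 in more than one place, so the wide gap between its value and theirs still cannot be tied to any single change, and this step says nothing about that gap.

The compounds shown leave open whether the reading would hold with a group other than fluoro or chloro at this place, such as a methoxy group, an amine or a carboxylic acid, since two neighbouring groups that match say little about the range this position allows. Why fluoro and chloro read alike here also stays open, as nothing given alongside these numbers bears on it.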